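Swapping a chloro for an amino on an inactive pair

This account rests on a few compounds, and the source may have more. Where it says the series, first, only, none or still open, it means among the compounds named here.

Of the compounds shown here, two of a shared core have been tested, and both sit at the edge of what the test can see. Compound 1, with the structure `Nc1nn(C(=O)Nc2ccc(Cc3ccccc3)cc2)c2ccccc12`, gives > 100000 nM in a functional assay on MDA-MB-231 cells (Homo sapiens) for antiproliferative activity, read by sulforhodamine B assay, with a stated time of 48 h (a lower number here means that less compound is tolerated, a higher number that more compound is tolerated), which is a limit of the test rather than a number. Compound 2, with the structure `Nc1nn(C(=O)Nc2ccc(Cc3ccccc3)cc2)c2ccc(Cl)cc12`, gives > 100000 nM in this assay, again a limit rather than a number. The change between them, chloro in place of hydrogen on an aromatic carbon, gives the step that the two limits leave unreadable from compound 1 to compound 2, so its size cannot be read. Within the data shown here, the only evidence on hand is the limit of > 100000 nM in this assay, at which 2 of the 2 values shown sit.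

Compound 3 has the structure `Nc1ccc2c(c1)c(N)nn2C(=O)Nc1ccc(Cc2ccccc2)cc1`. It differs from compound 2 by amino in place of chloro on an aromatic carbon. Among the measured compounds shown here, no measured step bears on this change in a readable way, so nothing points to a shift in either direction beyond the scatter. Compound 3 is therefore expected to sit at the same limit, an estimated step of a number no higher from compound 2 to compound 3 (the limit leaves the size open), and an estimated value of 100000 nM with a range from 30000 nM to 300000 nM.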

Compound 3, concentration lethal to 50% of the cells: 54300 nM
Compound 3: middle estimate off by 1.8-fold (0.27 log units), on the high side, and the stated range covers the measured number.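

Among these compounds, compound 3 gives the first value in this assay that is a number rather than a limit, so this position on the six-membered aromatic ring can now be tied to a readable result, which compound 1 and compound 2 could not provide. Amino in place of chloro gives an at least 1.8-fold lower number from compound 2 to compound 3 (0.26 log units; that floor lies within the scatter), and amino in place of hydrogen gives an at least 1.8-fold lower number from compound 1 to compound 3 (0.26 log units; that floor lies within the scatter). Both sizes are only floors, so neither step is shown to exceed the usual scatter, the step from hydrogen to chloro cannot be read, and the comparison rests on limits: the limit of > 100000 nM in this assay, at which 2 of the 3 values shown sit.

From the compounds shown here alone, the true distance between amino and the other two groups remains open, since it could be close to these floors or much larger. Going by these compounds, it is also open whether a hydroxyl, a methoxy, a dimethylamino or an acetamide group at this same place would give a number in this assay, and how such a number would compare with that of compound 3.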